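The source may hold more compounds than are shown below. What is called first, only, known or untested is meant among the compounds shown, and "the series" means these compounds.

In a functional assay on Jurkat cells (Homo sapiens) (on this read-out lower numbers stand for stronger inhibition and higher numbers for weaker inhibition), compound 1 `CC(C)[C@H](NC(=O)COc1cccc2ccccc12)C(=O)N[C@@H](CC(=O)O)C(=O)COc1cccc2ccccc12` returns only a limit, > 100000 nM. Compound 2 `CC(C)[C@H](NC(=O)COc1cccc2ccccc12)C(=O)N[C@@H](CC(=O)O)C(=O)COc1ccc(C(F)(F)F)cc1` likewise gives only a limit in this assay, > 100000 nM. The step that the two limits leave unreadable from compound 1 to compound 2 cannot be read, since both values sit at the limit of > 100000 nM in this assay, at which 2 of the 2 values shown sit. Compound 2 thus stands at the limit of this assay, with no measured number anywhere in the series to place it against. Compound 3 `CC(C)[C@H](NC(=O)COc1cccc2ccccc12)C(=O)N[C@@H](CC(=O)O)C(=O)COc1ccc([N+](=O)[O-])cc1F` differs from compound 2 by 2-fluoro-4-nitrophenyl in place of 4-(trifluoromethyl)phenyl on an oxygen on a saturated carbon. Within the data shown here, the only measured step touching the same position, a step that the two limits leave unreadable from compound 1 to compound 2, gave no readable size, so no direction beyond the scatter can be expected from it. The step expected here is a number no higher from compound 2 to compound 3 (the limit leaves the size open). For compound 3 in this assay the estimate is 100000 nM, between 30000 nM and 300000 nM, and the result is expected most likely to come back once more only as a limit rather than a number.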

Compound 3, half-maximal inhibitory concentration: 30300 nM
Compound 3: the middle estimate sits 3.3-fold (0.52 log units) above what was measured, within the range that was stated.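

In this assay compound 3 gives 30300 nM, the only number among the compounds shown, so the group on an oxygen on a saturated carbon does bear on this read-out. Placing 2-fluoro-4-nitrophenyl there gives an at least 3.3-fold lower number from compound 2 to compound 3 (0.51 log units; beyond the scatter) and an at least 3.3-fold lower number from compound 1 to compound 3 (0.51 log units; beyond the scatter), with the same group entering in both steps against 4-(trifluoromethyl)phenyl and naphthalen-1-yl. The true size of each step remains open-ended, because the starting value of each is a limit: the limit of > 100000 nM in this assay, at which 2 of the 3 values shown sit.

Which part of 2-fluoro-4-nitrophenyl accounts for these steps remains open, as the fluorine and the nitro group enter together and neither is seen alone. Also open, going by these compounds, is how a plain phenyl, a 4-nitrophenyl or a 4-aminophenyl group would read at this position.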